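This account rests on a few compounds, and the source may have more. Where it says the series, first, only, none or still open, it means among the compounds named here.

Compound 1 `O=C(CCCCCCc1ccccc1)c1nncs1` and compound 2 `O=Cc1coc(C(=O)CCCCCCc2ccccc2)n1` share a ketone chain that ends in a phenyl ring and differ only in the aromatic ring attached to the carbonyl carbon. In an assay on HEK-293T cells for inhibition of diacylglycerol lipase-alpha (Homo sapiens), read by colorimetric assay (a higher number here means a weaker inhibitor, a lower number a stronger inhibitor), compound 1 gives only a limit, > 10000 nM. Among the compounds with values here, compound 2 in this assay gives 1510 nM, the only number among the two values shown. The other value is a limit (the limit of > 10000 nM in this assay, at which 1 of the 2 values shown sits), belonging to compound 1. The step of an at least 6.6-fold lower number from compound 1 to compound 2 (0.82 log units; beyond the scatter) is thus at least modest. Compound 3 `O=C(CCCCCCc1ccccc1)c1nc(Br)co1` keeps the core of compound 2 and differs by bromo in place of formyl on an aromatic carbon. Within the data shown here, no measured step alters a substituent on that ring; the single measured step exchanges one ring for another, so it bears only loosely on this change. The step of a 2.0-fold higher number from compound 2 to compound 3 (0.30 log units; within the scatter) is therefore expected to be small, without a firm direction. Compound 3 is estimated at 3000 nM, between 800 nM and 10000 nM.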

Compound 3, half-maximal inhibitory concentration: > 10000 nM
Compound 3 gave a limit, no number (the forecaster's own chance of this, stated with the estimate: 25%); at least 3.3-fold (0.52 log units) between middle value and limit.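

With the rest of the core kept, replacing formyl by bromo on the aromatic carbon next to the ring nitrogen gives an at least 6.6-fold higher number from compound 2 to compound 3 (0.82 log units; beyond the scatter), so among these compounds the substituent at this place, and not only the choice of ring, separates a measurable value from a limit. The step between compound 1 and compound 3 cannot be read, as both values are limits. Compound 2 alone therefore carries a number, and the other two compounds share one limit: the limit of > 10000 nM in this assay, at which 2 of the 3 values shown sit.

On these data alone, how far compound 3 lies past its limit stays open, and with it the full size of this step. Also open, as far as these compounds go, is whether another group at this place, such as a nitrile, a carboxylic acid or a methyl ester, would match compound 2 at 1510 nM or improve on it.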